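A few compounds are considered here, and "the series" means these few. Any claim that something is new, unique, unknown or untested is made for them only; others in the source may bear on it.

Working notes on the series. Two compounds carry numbers in an assay on HEK293 cells for displacement of a labelled ligand from prostaglandin D2 receptor 2 (Homo sapiens); on this read-out higher numbers stand for weaker inhibition and lower numbers for stronger inhibition. Compound 1 `CCOC(=O)CCSc1nc2ccccc2n1CC(=O)O` gives 11400 nM. Compound 2 `Cc1ccccc1CSc1nc2ccccc2n1CC(=O)O` gives 810 nM, the lowest of the two numbers shown; the only neighbour is compound 1, and the step of a 14-fold lower number from compound 1 to compound 2 (1.15 log units; beyond the scatter) separates them. Compound 3 `O=C(O)Cn1c(SCc2cccc(Br)c2)nc2ccccc21` has not yet been measured in this assay. It differs from compound 2 in one place: 3-bromophenyl in place of 2-methylphenyl on a saturated chain carbon bound to a sulfur. Within the data shown here, only one measured step exists, and it bears on this change indirectly: the step of a 14-fold lower number from compound 1 to compound 2 (1.15 log units; beyond the scatter) shows that an aromatic ring on the saturated chain carbon bound to a sulfur, in place of the (ethoxycarbonyl)methyl chain, goes with a much lower number. Compound 3 keeps an aromatic ring in that place, so the large gain seen for compound 2 is expected to be kept. Nothing measured distinguishes a 3-bromophenyl from a 2-methylphenyl here, so no step beyond the scatter is expected in this assay, and the estimate for compound 3 is 700 nM, between 200 nM and 2500 nM; this corresponds to an expected step of a 1.2-fold lower number from compound 2 to compound 3 (0.06 log units; within the scatter).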

Compound 3, half-maximal inhibitory concentration: 370 nM
Beside the measured number, compound 3's estimate is 1.9-fold (0.28 log units) above it, within the range that was stated.
By their numbers in this assay, from the lowest: compound 3; then compound 2; then compound 1.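

Working notes, continued. In this assay, 3-bromophenyl in place of 2-methylphenyl on a saturated chain carbon bound to a sulfur gives a 2.2-fold lower number from compound 2 to compound 3 (0.34 log units; beyond the scatter), so this place still responds to a change between two aromatic groups, though only modestly. Set against the (ethoxycarbonyl)methyl chain, the 3-bromophenyl group gives a 31-fold lower number from compound 1 to compound 3 (1.49 log units; beyond the scatter), which shows that the large drop is not confined to the 2-methylphenyl group and now holds for both aromatic groups shown. The two exchanged groups match in heavy-atom count and each carries one six-membered aromatic ring of carbon only, yet no measurement on hand accounts for the modest difference between them.

Since the bromine replaces the methyl group and the name of the group also changes from 2 to 3, a 2-bromophenyl or a 3-methylphenyl group would be needed to separate the identity of the substituent from its place on the ring. As far as these compounds go, it also stays open whether this place needs an aromatic ring at all, and a cyclohexyl group or a plain benzyl extension of the chain would bear on that question.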